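This account rests on a few compounds, and the source may have more. Where it says the series, first, only, none or still open, it means among the compounds named here.

Measured so far:
Compound 1, `C=C(Br)C(=O)Nc1ccc(/C=C2\SC(=O)N(Cc3ccc(C)cc3)C2=O)cc1`, gives 6100 nM in a functional assay on FM3A cells (Mus musculus) for cytotoxicity, read by cell counting, with a stated time of 2 days; a lower number here means a stronger inhibitor, a higher number a weaker inhibitor.
Compound 2, `Nc1cccc(/C=C2\SC(=O)N(Cc3ccc(F)cc3)C2=O)c1`, gives 140000 nM in this assay.
Compound 3, `CC(C)(C)c1ccc(CN2C(=O)S/C(=C\c3ccc(N)cc3)C2=O)cc1`, gives 80000 nM in this assay.

Among these three numbers, compound 2 carries the highest one. Its neighbour is compound 3, whose number lies lower by an amount that stays within the usual scatter, so the two cannot be told apart. Compound 1 stands far lower, and that gap is well beyond the scatter.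

The next compound, compound 4, `Nc1cccc(/C=C2\SC(=O)N(Cc3ccccc3)C2=O)c1`, differs from compound 2 in one spot only: hydrogen in place of fluoro on an aromatic carbon. In other words, the fluoro on the six-membered aromatic ring of carbon only is replaced by hydrogen, and the rest of the shared core is untouched. Among the compounds with values here, no measured pair here shows this exact change, so the size of its effect in this assay is unknown. A swap of this kind removes a single small group, and the expectation is a step of no more than the scatter, with no clear direction. For compound 4 the expected value is 150000 nM, with a range from 60000 nM to 400000 nM. This corresponds to an expected step of a 1.1-fold higher number from compound 2 to compound 4 (0.03 log units; within the scatter).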

Compound 4, half-maximal inhibitory concentration: > 250000 nM
Compound 4: a limit, no number (the forecaster's own chance of this, stated with the estimate: 15%); middle value at least 1.6-fold (0.22 log units) from the limit.
By their numbers in this assay, from the lowest: compound 1; then compounds 3 and 2 (each within the scatter of the next). At a limit, above all of these: compound 4.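

Within the data shown here, this is the first pair that differs in one place only, so it isolates the swap of 4-fluorophenyl to phenyl, on an aromatic carbon para to a large group. In this assay, the step is an at least 1.7-fold higher number from compound 2 to compound 4 (0.25 log units; that floor lies within the scatter), so taking away the fluoro does not give a stronger inhibitor, yet the data cannot show that the fluoro helps either. Going by these compounds, the true size of the step stays unknown, since the reading for compound 4 is a limit of the assay and not a number: the limit of > 250000 nM in this assay, at which 1 of the 4 values shown sits.

The compounds shown leave open how a chloro or a methoxy group on this same aromatic carbon would read. They also leave open whether the fluoro counts for anything on a compound whose number lies well clear of the limit.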